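The compounds below may be only part of what the source reports. "The series", "measured", "known", "first", "only" and "open" are said of these compounds alone.

Of the compounds shown here, three have so far been measured in an assay on tissue (HeLa cells) for inhibition of Indoleamine 2,3-dioxygenase 1 (Homo sapiens), with a stated time of 48 h; on this read-out lower numbers stand for stronger inhibition and higher numbers for weaker inhibition. Compound 1 `NS(=O)(=O)N1CCC(C(=O)/C(=N/O)Nc2ccc(F)c(Br)c2)CC1` gives 45 nM in this assay. Compound 2 `O=C(/C(=N/O)Nc1ccc(F)c(Br)c1)[C@H]1CC[C@H](NS(=O)(=O)Nc2ccccc2)CC1` gives 291 nM in this assay, and compound 3 `O=C(Nc1ccccc1)[C@H]1CC[C@H](C(=O)/C(=N/O)Nc2ccc(F)c(Br)c2)CC1` gives 197 nM. Compound 1 therefore carries the lowest number of the three, and its separation from both compound 2 and compound 3 lies beyond the usual scatter, so within this small set it stands as the most potent member.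

Compound 4 `O=C(/C(=N/O)Nc1ccc(F)c(Br)c1)C1CCN(C(=O)Nc2ccccc2)CC1` has not yet been measured. It differs from compound 1 in one place: phenylcarbamoyl in place of sulfamoyl on an amine nitrogen in a ring. For the measured compounds named here, no measured pair shows exactly this exchange, so the size of the step cannot be read off directly. What the measured compounds do show is that the two members bearing a phenyl ring, compound 2 and compound 3, carry higher numbers than compound 1, each beyond the scatter. On that basis the step from compound 1 to compound 4 is expected to be a loss rather than a gain, estimated as a 4.4-fold higher number from compound 1 to compound 4 (0.65 log units; beyond the scatter). Compound 4 is accordingly expected to give about 200 nM in this assay, with a likely range from 70 nM to 600 nM.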

Compound 4, half-maximal inhibitory concentration: 54 nM
For compound 4 the middle estimate is 3.7-fold (0.57 log units) above the measured one; measured number outside the range, below it.
By their numbers in this assay, from the lowest: compounds 1 and 4 (each within the scatter of the next); then compounds 3 and 2 (each within the scatter of the next).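

Where the ring nitrogen of the core of compound 1 carries sulfamoyl, phenylcarbamoyl in its place gives a 1.2-fold higher number from compound 1 to compound 4 (0.08 log units; within the scatter) in this assay, so this position accepts a group of 9 heavy atoms with a six-membered aromatic ring without leaving the scatter of the group of 4 heavy atoms that has no ring. At this position, then, the phenyl ring does not go with a higher number, even though compound 2 and compound 3 also carry a phenyl ring and do show higher numbers; those two differ from compound 1 in more than one place, so they cannot isolate the effect of that ring. Nothing available here accounts for the two groups reading alike.

The compounds shown leave open how far this acceptance extends on the ring nitrogen, for instance to a benzyl group, an acetyl group or a phenylcarbamoyl with a chlorine on its ring. They also leave open whether a phenylsulfamoyl group on the same nitrogen would read like phenylcarbamoyl.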